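From a Phenyl to a Pyridyl on the Hydrazone Carbon

This account rests on a few compounds, and the source may have more. Where it says the series, first, only, none or still open, it means among the compounds named here.

Measured so far:
Compound 1 `CCCCC/C=C/C=C/C=N/Nc1nc(N)c2ncn([C@@H]3O[C@H](CO)[C@@H](O)[C@H]3O)c2n1`: 2 nM
Compound 2 `CC(=O)Nc1ccc(/C=N/Nc2nc(N)c3ncn([C@@H]4O[C@H](CO)[C@@H](O)[C@H]4O)c3n2)cc1`: > 10000 nM (a limit of the assay)
Compound 3 `CCOc1cc(/C=N/Nc2nc(N)c3ncn([C@@H]4O[C@H](CO)[C@@H](O)[C@H]4O)c3n2)ccc1O`: 6940 nM

All three share one core and differ only in the group on the carbon with a double bond to nitrogen. In an assay on CHO-K1 cells for displacement of a labelled ligand from adenosine receptor A1 (Homo sapiens), read by scintillation counting, with a stated time of 60 min (a higher number here means a weaker inhibitor, a lower number a stronger inhibitor), compound 1 gives 2 nM. For compound 2 this assay reports only a limit, > 10000 nM, not a number. Compound 3 gives 6940 nM and so has the highest of the two numbers shown; the move a 3500-fold higher number from compound 1 to compound 3 (3.54 log units; beyond the scatter) is large, as is an at least 5000-fold higher number from compound 1 to compound 2 (3.69 log units; beyond the scatter). Between the two aromatic compounds the step of an at least 1.4-fold lower number from compound 2 to compound 3 (0.15 log units; that floor lies within the scatter) is small.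

Compound 4 `COc1ccc(/C=N/Nc2nc(N)c3ncn([C@@H]4O[C@H](CO)[C@@H](O)[C@H]4O)c3n2)cn1` has not yet been measured. It differs from compound 3 as follows: 6-methoxypyridin-3-yl in place of 3-ethoxy-4-hydroxyphenyl on a carbon with a double bond to nitrogen. This is again a swap of one aromatic group for another on the same carbon, the kind of swap seen in an at least 1.4-fold lower number from compound 2 to compound 3 (0.15 log units; that floor lies within the scatter), which stayed within the scatter, while the only large steps shown, an at least 5000-fold higher number from compound 1 to compound 2 (3.69 log units; beyond the scatter) and a 3500-fold higher number from compound 1 to compound 3 (3.54 log units; beyond the scatter), belong to the loss of the chain. The step of a 1.4-fold higher number from compound 3 to compound 4 (0.16 log units; within the scatter) is therefore expected to be small. Compound 4 is estimated at 10000 nM, with a likely range from 3000 nM to 30000 nM, and the assay may well report only a limit.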

Compound 4, inhibition constant: 2.6 nM
Compound 4: middle estimate off by 3800-fold (3.59 log units), on the high side; the measured number lies below the stated range.
By their numbers in this assay, from the lowest: compounds 1 and 4 (each within the scatter of the next); then compound 3. At a limit, above all of these: compound 2.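

The aromatic group on the carbon with a double bond to nitrogen turns out to matter as much as the loss of the chain: in this assay, 6-methoxypyridin-3-yl gives a 2700-fold lower number from compound 3 to compound 4 (3.43 log units; beyond the scatter), and against 4-acetamidophenyl it gives an at least 3800-fold lower number from compound 2 to compound 4 (3.58 log units; beyond the scatter). An aromatic ring in this place is therefore not in itself what separates compound 2 and compound 3 from compound 1, since the pyridine-bearing compound matches the compound with the chain, with a 1.3-fold higher number from compound 1 to compound 4 (0.11 log units; within the scatter). Compound 2 has no exact number, only a limit, so its step gives a floor and not a true size: the limit of > 10000 nM in this assay, at which 1 of the 4 values shown sits.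

The step to compound 4 changes several things at once: a ring with one hetero atom enters, a methoxy group enters, and both the hydroxy and the ethoxy groups leave, so the compounds shown cannot assign the large step to any one of these. From the compounds shown here alone, it remains open whether a plain pyridyl ring without the methoxy, or a phenyl ring carrying only a methoxy, would keep a number close to that of compound 4 in this assay.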